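Removing the carboxypropyl amide substituent in a sirtuin-6 series

The source may hold more compounds than are shown below. What is called first, only, known or untested is meant among the compounds shown, and "the series" means these compounds.

Measured compounds:
Compound 1, `CCNC(=O)CCCSC[C@H](NC(=O)OCc1ccccc1)C(=O)Nc1ccccc1`, gives 15% in an assay for inhibition of NAD-dependent protein deacylase sirtuin-6 (Homo sapiens), read by HPLC, with stated times of 15 min and 1 h, tested at 333 uM; a lower number here means less inhibition, a higher number more inhibition at the concentration tested (going by the name of the read-out).
Compound 2, `O=C(O)CCCNC(=O)CCCSC[C@H](NC(=O)OCc1ccccc1)C(=O)Nc1ccccc1`, gives 35% in this assay.

Among the compounds with values here, compound 2 holds the higher of the two numbers measured so far, and the only measured step, a number 20 percentage points higher from compound 1 to compound 2 (beyond the scatter), shows that adding a carboxymethyl to the chain end raised inhibition beyond the scatter. Compound 3, `NC(=O)CCCSC[C@H](NC(=O)OCc1ccccc1)C(=O)Nc1ccccc1`, differs from compound 2 by hydrogen in place of 3-carboxypropyl on an amide-type nitrogen. This removes the whole 3-carboxypropyl chain, including the carboxylic acid whose introduction gave the gain seen in the step from compound 1 to compound 2. Within the data shown here, that step is the only one bearing on the change; it points to a drop in this assay of roughly the same size, because a number 20 percentage points higher from compound 1 to compound 2 (beyond the scatter) was the gain. Compound 3 is therefore expected to show a step of a number 20 percentage points lower from compound 2 to compound 3 (beyond the scatter). The estimate for compound 3 is 15%, with a range from 0% to 32%.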

Compound 3, a percentage reported as inhibition, at one concentration (the size of the read-out at that concentration, not a potency): 11%
Estimate against measurement, compound 3: 4 percentage points above; the range from low to high includes it.
By their numbers in this assay, from the lowest: compounds 3 and 1 (each within the scatter of the next); then compound 2.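

Putting hydrogen in place of 3-carboxypropyl on the amide-type nitrogen gives a number 24 percentage points lower from compound 2 to compound 3 (beyond the scatter) in this assay, so the inhibition seen with compound 2 does not survive loss of the whole group. Hydrogen in place of ethyl on that nitrogen gives a number 4 percentage points lower from compound 1 to compound 3 (within the scatter), so the ethyl and the bare amide cannot be told apart, and of the three groups compared at this position, only 3-carboxypropyl stands out. Nothing available here explains why this group stands out.

Still open, going by these compounds, is whether the carboxylic acid itself matters or the length of the chain that carries it, a question that a plain butyl chain or a chain ending in an amine could help to settle. A shorter or longer chain ending in a carboxylic acid would show how much the distance from the nitrogen counts.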